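Meta Substituent Swap on a Three-Compound Azetidinone Series

The source may hold more compounds than are shown below. What is called first, only, known or untested is meant among the compounds shown, and "the series" means these compounds.

Compound 3 `COC(=O)/C(=C/c1ccccc1)CN1C(=O)[C@@H](OC)[C@H]1c1ccccc1` gives 11100 nM in a functional assay on MDA-MB-231 cells (Homo sapiens) for antiproliferative activity, read by MTT assay, with a stated time of 48 h; a higher number here means a weaker inhibitor, a lower number a stronger inhibitor. Among the three measured compounds it carries the lowest number: compound 1 `CCOC(=O)/C(=C/c1ccccc1)CN1C(=O)[C@@H](OC)[C@H]1c1cccc([N+](=O)[O-])c1` gives 14400 nM, which lies within the scatter of compound 3, while compound 2 `COC(=O)/C(=C/c1ccccc1)CN1C(=O)[C@@H](OC)[C@H]1c1cccc(F)c1` gives 34400 nM, the furthest away. Going by the values given here, the only single-point step measured so far is a 3.1-fold lower number from compound 2 to compound 3 (0.49 log units; beyond the scatter), so the one aromatic substitution on record pulled the number down by a modest but real amount once the substituent was gone.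

Compound 4 `COC(=O)/C(=C/c1ccccc1)CN1C(=O)[C@@H](OC)[C@H]1c1cccc([N+](=O)[O-])c1` is the unmeasured neighbour of compound 3. The change is nitro in place of hydrogen on an aromatic carbon. Among the compounds with values here, no measured step introduces this group onto this position, so its effect cannot be read off directly. Compound 1 carries the same nitro group and differs from compound 4 only in the ester, and its number is within the scatter of compound 3; that is the most relevant comparison available. Adding a substituent where removing a different one lowered the number suggests, if anything, a small rise. He therefore expects compound 4 to sit close to compound 3, with a step of a 1.3-fold higher number from compound 3 to compound 4 (0.10 log units; within the scatter), and estimates a value of 14000 nM, in a range from 7000 nM to 30000 nM.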

Compound 4, half-maximal inhibitory concentration: 14400 nM
For compound 4 the middle estimate is 1.0-fold (0.01 log units) below the measured one, and the stated range covers the measured number.
By their numbers in this assay, from the lowest: compounds 3, 1 and 4 (each within the scatter of the next); then compound 2.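

In this assay, going by these compounds alone, nitro in place of hydrogen on this aromatic carbon, meta to a large group, gives a 1.3-fold higher number from compound 3 to compound 4 (0.11 log units; within the scatter) and so gives the first direct reading of this change, which leaves compound 4 within the scatter of compound 3. Fluoro is what stands apart here, since nitro in place of fluoro gives a 2.4-fold lower number from compound 2 to compound 4 (0.38 log units; beyond the scatter) and hydrogen in place of fluoro gives a 3.1-fold lower number from compound 2 to compound 3 (0.49 log units; beyond the scatter) in the same assay, so a substituent at this position does not by itself go with the higher number of compound 2, and compound 4 goes against any such reading. The ester can now be read on its own as well: hydrogen in place of methyl on the saturated chain carbon bound to an oxygen next to a carbonyl group gives no change at the digits printed from compound 1 to compound 4 (within the scatter) with the nitro group in place.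

The compounds shown leave open whether an amine or a carboxylic acid on this aromatic carbon would carry the number beyond the scatter of compound 3, and whether a longer chain on the ester would hold it there. Nothing measured here explains why fluoro differs from nitro and hydrogen at this position.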